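The compounds below may be only part of what the source reports. "The series", "measured", "known", "first", "only" and "open" are said of these compounds alone.

In an ADME assay on HEK293 cells (Homo sapiens) for cytotoxicity, read by MTT assay, with a stated time of 24 h (on this read-out higher numbers stand for weaker inhibition and lower numbers for stronger inhibition), the cytotoxicity of a small set of compounds sharing one core was recorded. Compound 1 `O=C1/C(=C/c2ccccc2F)CN(Cc2cn(Cc3ccc(F)cc3)nn2)C/C1=C\c1ccccc1F` gives 46000 nM in this assay. Compound 2 `O=C1/C(=C/c2ccccc2F)CN(Cc2cn(Cc3ccccc3Cl)nn2)C/C1=C\c1ccccc1F` gives 33200 nM in this assay, and the shift a 1.4-fold lower number from compound 1 to compound 2 (0.14 log units; within the scatter) leaves the two numbers within the scatter of each other. Compound 3 `COc1ccc(/C=C2\CN(Cc3cn(Cc4ccc(F)cc4)nn3)C/C(=C\c3ccc(OC)cc3)C2=O)cc1` was included in the set, but in this assay compound 3 gives "not determined" (no result reported), that is, no result was reported for it. Among the compounds with values here, on the numbers in hand, compound 2 therefore has only one neighbour, compound 1, and the gap between them is within the scatter; nothing separates them.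

Compound 4 `O=C1/C(=C/c2ccccc2F)CN(Cc2cn(Cc3ccccc3F)nn2)C/C1=C\c1ccccc1F` is the next member. It differs from compound 2 by fluoro in place of chloro on an aromatic carbon. Within the data shown here, the only measured step that bears on this part of the molecule is the one from compound 1 to compound 2, which exchanged one halogenated phenyl for another and moved the number by an amount within the scatter. A single halogen exchange on that same ring is expected to behave alike, so the step of a 1.2-fold higher number from compound 2 to compound 4 (0.08 log units; within the scatter) is estimated to fall within the scatter. Compound 4 is accordingly expected to give about 40000 nM in this assay, with a plausible range from 20000 nM to 80000 nM.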

Compound 4, half-maximal inhibitory concentration: 41200 nM
Beside the measured number, compound 4's estimate is 1.0-fold (0.01 log units) below it; the measured number falls inside the stated range.
By their numbers in this assay, from the lowest: compounds 2, 4 and 1 (each within the scatter of the next).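

In this assay, within the data shown here, fluoro in place of chloro on the aromatic carbon ortho to a large group gives a 1.2-fold higher number from compound 2 to compound 4 (0.09 log units; within the scatter), so the two halogens are not told apart at this position, a comparison that the earlier compounds, which changed the halogen and its place together, could not offer on its own. The second new comparison isolates the place of the fluoro: 2-fluorophenyl in place of 4-fluorophenyl gives a 1.1-fold lower number from compound 1 to compound 4 (0.05 log units; within the scatter), so these two placements are not told apart either, and the three halogenated rings of compounds 1, 2 and 4 form one group within the scatter. Nothing at hand offers an explanation for how closely these numbers sit together.

As far as these compounds go, since every ring with a number here carries a halogen, it remains open whether an amine, a carboxylic acid or a longer chain on that ring would leave the number equally unmoved. From the compounds shown here alone, compounds 1, 2 and 4 also share the rest of their structure, and compound 3, which differs elsewhere, offers no number, so how the cytotoxicity responds to changes away from this ring remains open as well.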